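Half-life in human microsomes: compound 1 to compound 4

The source may report more compounds than this note shows. Statements on the series, on what has been measured and on what is new or still open speak of the compounds shown alone.

Measured so far:
compound 1 `CCc1nc(-c2ccc(Cl)cc2Cl)c(CC)nc1NC(COC)COC`: 0.15 h
compound 2 `CCc1nc(-c2ccc(OC(F)F)cc2Cl)c(OC)nc1NC(CC)CC`: 2 h
compound 3 `CCc1nc(-c2cnc(OC)nc2OC)c(CC)nc1NC(CC)CC`: 0.117 h

In an in vitro ADME assay on microsomes (Homo sapiens) for metabolic stability (a higher number here means that the compound lasts longer, a lower number that the compound disappears faster), compound 1 gives 0.15 h, the second highest of the three numbers. Compound 3 sits within the scatter of it; compound 2 stands well beyond, with the highest number of the set. For the measured compounds named here, no single-point step between measured compounds exists.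

Compound 4 `CCc1nc(-c2ccc(Cl)cc2Cl)c(CC)nc1NC(CC)CC` differs from compound 1 in one place: pentan-3-yl in place of 2-methoxy-1-(methoxymethyl)ethyl on a nitrogen on an aromatic ring. The same pentan-3-yl on a nitrogen on an aromatic ring is present in compound 3, whose number lies within the scatter of compound 1, and in compound 2, whose number is far higher but on a different core and aryl. For compound 4 the step of no change at the digits printed from compound 1 to compound 4 (within the scatter) is expected to stay within the scatter, with 0.15 h estimated, ranging from 0.05 h to 0.5 h.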

Compound 4, half-life: 0.283 h
Compound 4: the middle estimate sits 1.9-fold (0.28 log units) below what was measured; the range from low to high includes it.
By their numbers in this assay, from the lowest: compounds 3, 1 and 4 (each within the scatter of the next, the first and the last beyond it); then compound 2.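

For the compounds shown here, at this position, on a nitrogen on an aromatic ring, pentan-3-yl in place of 2-methoxy-1-(methoxymethyl)ethyl gives the first single-change reading in this assay (a 1.9-fold higher number from compound 1 to compound 4 (0.28 log units; within the scatter)), and that step lies within the scatter. On this core, then, the half-life does not separate the chain with 2 hydrogen-bond acceptors from the chain with 0. No measurement at hand bears on why this is so.

Open, as far as these compounds go, is whether a longer chain, a cyclopentyl ring or a chain carrying an amine on this nitrogen would give a half-life beyond the scatter of compound 1 and compound 4.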